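Carboxy in place of aminocarbamoyl on a shared core

The compounds below may be only part of what the source reports. "The series", "measured", "known", "first", "only" and "open" are said of these compounds alone.

Of the compounds shown here, two built on a shared core have been measured in an assay on a protein complex for inhibition of CDK8/Cyclin C (Homo sapiens), with a stated time of 1 h; on this read-out lower numbers stand for stronger inhibition and higher numbers for weaker inhibition. Compound 1 `CCOC(=O)/C=C/c1ccncc1-c1ccc2c(cnn2C)c1` gives 102 nM. Compound 2 `NNC(=O)CCc1ccncc1-c1ccc2ccccc2c1` gives 7.7 nM, the lowest of the two numbers; its nearest neighbour is compound 1, whose number lies higher by a margin beyond the usual scatter. Compound 3 `O=C(O)CCc1ccncc1-c1ccc2ccccc2c1` awaits measurement in this assay. It differs from compound 2 in one place: hydroxy in place of aminoamino on a carbonyl carbon. Going by the values given here, no measured pair differs in only this place, so no measured step tells how this change plays out, and the gap between compound 1 and compound 2 spans several changes at once. For compound 3 the expected step is a 3.2-fold higher number from compound 2 to compound 3 (0.51 log units; beyond the scatter), a modest move toward weaker inhibition, though a result within the scatter would not surprise. Compound 3 is therefore estimated at 25 nM, with a range from 6 nM to 100 nM.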

Compound 3, half-maximal inhibitory concentration: 50.5 nM
Compound 3: middle estimate off by 2.0-fold (0.31 log units), on the low side; the range from low to high includes it.
By their numbers in this assay, from the lowest: compound 2; then compound 3; then compound 1.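

In this assay, going by these compounds alone, the change from aminocarbamoyl to carboxy gives a 6.6-fold higher number from compound 2 to compound 3 (0.82 log units; beyond the scatter) and so supplies the first measured step at this place, the carbonyl carbon at the end of the chain. Only the group on that carbon differs, a hydroxy for an aminoamino, so the step belongs to this one change alone. The position thus responds to what stands on the carbonyl carbon, yet with carboxy in place compound 3 still gives 50.5 nM and inhibition is weakened rather than lost.

Going by these compounds, whether a methyl ester, a primary amide, an amine or a longer chain at this place would fall nearer compound 2 or compound 3 stays open, as does whether the same change would act alike on the core of compound 1. Nothing measured here gives a reason for the step.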